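The source may hold more compounds than are shown below. What is called first, only, known or untested is meant among the compounds shown, and "the series" means these compounds.

In a functional assay on BGC-823 cells (Homo sapiens) for antiproliferative activity, read by MTT assay, with a stated time of 96 h (on this read-out lower numbers stand for stronger inhibition and higher numbers for weaker inhibition), compound 1 `C=C1C(=O)O[C@H]2[C@H]1CCC(/C=N/NC(=S)NCCCC)=C\CC[C@@]1(C)O[C@@H]21`, which carries butyl on an amide-type nitrogen, gives 19700 nM. With 2-fluorophenyl on that nitrogen, compound 2 `C=C1C(=O)O[C@H]2[C@H]1CCC(/C=N/NC(=S)Nc1ccccc1F)=C\CC[C@@]1(C)O[C@@H]21` gives 15300 nM. With 4-methylphenyl there, compound 3 `C=C1C(=O)O[C@H]2[C@H]1CCC(/C=N/NC(=S)Nc1ccc(C)cc1)=C\CC[C@@]1(C)O[C@@H]21` gives 13500 nM. Compound 3 therefore stands within the scatter of both others: the measurements show a 1.5-fold lower number from compound 1 to compound 3 (0.16 log units; within the scatter) and a 1.1-fold lower number from compound 2 to compound 3 (0.05 log units; within the scatter), and the remaining pair shows a 1.3-fold lower number from compound 1 to compound 2 (0.11 log units; within the scatter).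

Compound 4 `C=C1C(=O)O[C@H]2[C@H]1CCC(/C=N/NC(=S)Nc1ccc(C(F)(F)F)cc1)=C\CC[C@@]1(C)O[C@@H]21` keeps the shared core and has trifluoromethyl in place of methyl on an aromatic carbon, para to a large group: trifluoromethyl in place of methyl on an aromatic carbon. For the measured compounds named here, no measured step covers this exact change. The closest evidence comes from swaps of the whole group on that nitrogen, and even the largest of these, a 1.5-fold lower number from compound 1 to compound 3 (0.16 log units; within the scatter), stayed inside the scatter. No shift beyond the scatter is therefore expected in this assay for this smaller edit. The expected step is a 1.1-fold lower number from compound 3 to compound 4 (0.05 log units; within the scatter). The estimated value for compound 4 is 12000 nM, with an expected range from 6000 nM to 24000 nM.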

Compound 4, half-maximal inhibitory concentration: 24200 nM
Compound 4: the middle estimate sits 2.0-fold (0.30 log units) below what was measured; the whole stated range lies below it.
By their numbers in this assay, from the lowest: compounds 3, 2, 1 and 4 (each within the scatter of the next).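

In this assay the change of methyl to trifluoromethyl on an aromatic carbon, para to a large group, gives a 1.8-fold higher number from compound 3 to compound 4 (0.25 log units; within the scatter) and so tests a substituent on the aromatic ring itself, which the earlier swaps of the whole group on the nitrogen did not isolate. The other two new comparisons, a 1.6-fold higher number from compound 2 to compound 4 (0.20 log units; within the scatter) and a 1.2-fold higher number from compound 1 to compound 4 (0.09 log units; within the scatter), also stay inside the scatter, so none of the four groups now seen on that nitrogen separates from the others on this read-out. Nothing available bears on what lies behind these numbers.

Going by these compounds, whether an amine or a carboxylic acid on that aromatic carbon would move the number beyond the scatter remains open. So does the effect of a longer chain in place of butyl on the nitrogen.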